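The compounds below may be only part of what the source reports. "The series", "measured", "known", "first", "only" and "open" are said of these compounds alone.

Measured in a functional assay on BGC-823 cells (Homo sapiens) for inhibition, read by MTT assay, with a stated time of 72 h; a lower number here means a stronger inhibitor, a higher number a weaker inhibitor:
- compound 1 `Cc1cc(N2CC[C@@H](C)[C@@H](N(C)c3ncnc4[nH]ccc34)C2)n2nc(SCc3csc4ccc(Cl)cc34)nc2n1`: > 100000 nM, which is a limit of the assay and not a number
- compound 2 `Cc1cc(N2CC[C@@H](C)[C@@H](N(C)c3ncnc4[nH]ccc34)C2)n2nc(SCc3ccc(F)cc3)nc2n1`: 44300 nM
- compound 3 `Cc1cc(N2CC[C@@H](C)[C@@H](N(C)c3ncnc4[nH]ccc34)C2)n2nc(SCC3CCCCC3)nc2n1`: 16300 nM

Of these three, compound 3 is the strongest inhibitor, although its value of 16300 nM is still a weak one on this scale. Compound 4 `Cc1cc(N2CC[C@@H](C)[C@@H](N(C)c3ncnc4[nH]ccc34)C2)n2nc(SCc3ccc(Br)cc3)nc2n1` keeps the shared core and changes one group: 4-bromophenyl in place of cyclohexyl on a saturated chain carbon bound to a sulfur. In words, 4-bromophenyl takes the place of cyclohexyl on a saturated chain carbon bound to a sulfur.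

The most relevant evidence is a 2.7-fold lower number from compound 2 to compound 3 (0.43 log units; beyond the scatter), a modest step in which cyclohexyl replaced 4-fluorophenyl at this same place. The other two steps, an at least 2.2-fold lower number from compound 1 to compound 2 (0.35 log units; beyond the scatter) and an at least 6.1-fold lower number from compound 1 to compound 3 (0.78 log units; beyond the scatter), start from a limit, so they give only a minimum size. Both still show that the group at this place matters. Going from cyclohexyl back to an aromatic ring should therefore reverse the modest gain, moving the number upward and making the inhibitor weaker. The expected change is a 2.8-fold higher number from compound 3 to compound 4 (0.44 log units; beyond the scatter). For compound 4 the estimated value is 45000 nM, with an expected range of 18000 nM to 100000 nM.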

Compound 4, half-maximal inhibitory concentration: 28000 nM
For compound 4 the middle estimate is 1.6-fold (0.21 log units) above the measured one, and the stated range covers the measured number.
By their numbers in this assay, from the lowest: compounds 3, 4 and 2 (each within the scatter of the next, the first and the last beyond it). At a limit, above all of these: compound 1.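

In this assay, a 1.7-fold higher number from compound 3 to compound 4 (0.23 log units; within the scatter) lies within the scatter, so 4-bromophenyl and cyclohexyl cannot be told apart at this place, and an aromatic ring here does not clearly weaken the inhibitor. With a 1.6-fold lower number from compound 2 to compound 4 (0.20 log units; within the scatter) also within the scatter, bromo and fluoro on the aromatic carbon cannot be told apart either. Compound 1 stands at a limit of the assay and not a number, so an at least 3.5-fold lower number from compound 1 to compound 4 (0.55 log units; beyond the scatter) gives only a minimum size, yet it still separates the 5-chloro-1-benzothiophen-3-yl group from 4-bromophenyl: the limit of > 100000 nM in this assay, at which 1 of the 4 values shown sits.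

All the groups shown on this saturated chain carbon bound to a sulfur are ring groups, and the measured numbers all remain weak. As far as these compounds go, whether an amine, a carboxylic acid or a longer chain at this place would give a clearly stronger inhibitor remains open.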